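The source may report more compounds than this note shows. Statements on the series, on what has been measured and on what is new or still open speak of the compounds shown alone.

Within the data shown here, in an ADME assay on HaCaT cells (Homo sapiens) for inhibition (a higher number here means a weaker inhibitor, a lower number a stronger inhibitor), compound 2 `COc1cc(-c2cc(C(=O)O)c3ccccc3n2)ccc1OCC(=O)Nc1ccccc1Cl` gives 210000 nM, the only plain number among the three measured compounds. Compound 1 `COc1cc(-c2cc(C(=O)O)c3ccccc3n2)ccc1OCC(=O)Nc1ccc(C)cc1` gives only a limit of the assay, > 300000 nM. Compound 3 `COc1cc(-c2cc(C(=O)O)c3ccccc3n2)ccc1OCC(=O)NCc1ccco1` likewise gives only a limit, > 300000 nM. Among the measured compounds shown here, compound 2 thus stands as the single number, with the two others at the limit of > 300000 nM in this assay, at which 2 of the 3 values shown sit. Compound 4 `CCCCCCNC(=O)COc1ccc(-c2cc(C(=O)O)c3ccccc3n2)cc1OC` differs from compound 2 by hexyl in place of 2-chlorophenyl on an amide-type nitrogen. For the measured compounds named here, no measured step swaps an aromatic group for a chain; the nearest comparisons are an at least 1.4-fold lower number from compound 1 to compound 2 (0.15 log units; that floor lies within the scatter) and an at least 1.4-fold higher number from compound 2 to compound 3 (0.15 log units; that floor lies within the scatter), both only at the floor of the scatter, while a step that the two limits leave unreadable from compound 1 to compound 3 cannot be read. A modest rise in this assay is therefore expected, a 1.7-fold higher number from compound 2 to compound 4 (0.22 log units; within the scatter), most likely ending again at a limit. Compound 4 is estimated at 350000 nM, between 150000 nM and 1000000 nM.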

Compound 4, half-maximal inhibitory concentration: > 300000 nM
Compound 4: no number, only a limit (the forecaster's own chance of this, stated with the estimate: 65%); the middle value does not contradict the limit.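

In this assay compound 4 gives only a limit, and a hexyl chain on the amide-type nitrogen thus ends where the 4-methylphenyl and (furan-2-yl)methyl groups ended: the limit of > 300000 nM in this assay, at which 3 of the 4 values shown sit.

Replacing 2-chlorophenyl with hexyl gives an at least 1.4-fold higher number from compound 2 to compound 4 (0.15 log units; that floor lies within the scatter), so this change brings no gain in inhibition, and a chain without a ring does not restore a plain number. The steps from compound 3 to compound 4 and from compound 1 to compound 4 cannot be read, since both ends are limits.

On these data alone, whether a propyl chain, or a group carrying an amine or a carboxylic acid, on this nitrogen would give a plain number stays open.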